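Aryl swap ortho to the amine: compound 4 estimate

The compounds below may be only part of what the source reports. "The series", "measured", "known", "first", "only" and "open" are said of these compounds alone.

Compound 1 `COc1ccc(-c2cc(C(=O)/C=C/c3cccc(OC)c3OC)ccc2N)cc1OC` gives 11900 nM in an assay on A549 cells for inhibition of transcription factor p65 (Homo sapiens), read by fluorescence, with a stated time of 2 h (on this read-out higher numbers stand for weaker inhibition and lower numbers for stronger inhibition), the second highest of the three numbers. Compound 2 `COc1ccc(/C=C/C(=O)c2cccc(-c3cccc(F)c3)c2)cc1OC` gives 33400 nM and compound 3 `COc1ccc(/C=C/C(=O)c2ccc(N)c(-c3ccc(OC)c(OC)c3)c2)c(OC)c1` gives 1700 nM. For the measured compounds named here, the only single-point step measured, a 7.0-fold lower number from compound 1 to compound 3 (0.85 log units; beyond the scatter), concerns the chain-bound aryl group and not the ring changed here. Compound 4 `COc1cccc(/C=C/C(=O)c2ccc(N)c(-c3ccc(F)cc3)c2)c1OC` differs from compound 1 by 4-fluorophenyl in place of 3,4-dimethoxyphenyl on an aromatic carbon. Going by the values given here, no measured step touches this position; compound 2, which carries a fluorophenyl on a core lacking the amino group, shows a higher number than compound 1, but the two differ in more than one place. The estimate for compound 4 is 16000 nM, with a range of 5000 nM to 50000 nM. The expected step is a 1.3-fold higher number from compound 1 to compound 4 (0.13 log units; within the scatter), small and possibly within the scatter.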

Compound 4, half-maximal inhibitory concentration: 13800 nM
The estimate for compound 4 lay 1.2-fold (0.06 log units) above the measured number; measured number inside the range.
By their numbers in this assay, from the lowest: compound 3; then compounds 1 and 4 (each within the scatter of the next); then compound 2.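

In this assay, for the compounds shown here, a 1.2-fold higher number from compound 1 to compound 4 (0.06 log units; within the scatter) is the first measured step at this aromatic carbon ortho to an amino group. On the core of compound 1, a group without hydrogen-bond acceptors thus replaces one carrying them with no step beyond the scatter. No available evidence bears on this result. On these data alone, whether a morpholine or a carboxylic acid at this carbon would give a step beyond the scatter remains open. Also open, as far as these compounds go, is whether 4-fluorophenyl gives the same outcome alongside the 2,4-dimethoxyphenyl group of compound 3.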